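The source may hold more compounds than are shown below. What is called first, only, known or untested is meant among the compounds shown, and "the series" means these compounds.

Compound 1 `CN(C(=O)NC(=O)c1c(F)cccc1F)c1nc(C(F)(F)F)c(C(=O)N/N=C/c2cc(C(F)(F)F)cc(C(F)(F)F)c2)s1`: 5.62 ug/mL
Compound 2 `CN(C(=O)NC(=O)c1ccc(F)c(F)c1)c1nc(C(F)(F)F)c(C(=O)N/N=C/c2cc(C(F)(F)F)cc(C(F)(F)F)c2)s1`: 4.45 ug/mL
Compound 3 `CN(C(=O)NC(=O)c1c(F)cccc1F)c1nc(C(F)(F)F)c(C(=O)N/N=C/c2cccc(C(F)(F)F)c2)s1`: 21.6 ug/mL

In a functional assay on HeLa cells (Homo sapiens) for inhibition, read by MTT assay, with a stated time of 72 h (on this read-out higher numbers stand for weaker inhibition and lower numbers for stronger inhibition), compound 1 stands second highest of these three numbers. Compound 2 lies within the scatter of it, a 1.3-fold lower number from compound 1 to compound 2 (0.10 log units; within the scatter), whereas compound 3 sits further away, a 3.8-fold higher number from compound 1 to compound 3 (0.58 log units; beyond the scatter), a modest step. Compound 4 `Cc1nc(N(C)C(=O)NC(=O)c2c(F)cccc2F)sc1C(=O)N/N=C/c1cc(C(F)(F)F)cc(C(F)(F)F)c1` differs from compound 1 by methyl in place of trifluoromethyl on an aromatic carbon. For the measured compounds named here, no measured step touches this part of the shared core, so the only guide is the loss of a trifluoromethyl seen in compound 3, a 3.8-fold higher number from compound 1 to compound 3 (0.58 log units; beyond the scatter), which weakened inhibition modestly. A weakening of similar size is therefore expected, a 2.1-fold higher number from compound 1 to compound 4 (0.33 log units; beyond the scatter). In this assay compound 4 is expected to give about 12 ug/mL, with a likely range from 4.5 ug/mL to 30 ug/mL.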

Compound 4, half-maximal inhibitory concentration: 12.2 ug/mL
Estimate against measurement, compound 4: 1.0-fold (0.01 log units) below; low and high end bracket the measured number.
By their numbers in this assay, from the lowest: compounds 2 and 1 (each within the scatter of the next); then compounds 4 and 3 (each within the scatter of the next).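

The trifluoromethyl on this ring carbon, next to the ring nitrogen, is not freely exchangeable in this assay: with methyl in its place, inhibition weakens modestly (a 2.2-fold higher number from compound 1 to compound 4 (0.34 log units; beyond the scatter)). For the compounds shown here, the earlier steps changed only the two outer aromatic rings, so this is the first reading from the shared core itself. No measurement shown here explains this loss. From the compounds shown here alone, whether a chlorine atom or an ethyl group on this carbon would restore inhibition stays open, as does whether the same change costs as much alongside the 3,4-difluorophenyl of compound 2.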